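This account rests on a few compounds, and the source may have more. Where it says the series, first, only, none or still open, it means among the compounds named here.

Working notes on the series. Compound 1 `CN(Cc1ccc(C(=O)O)cc1)c1ccc(OCc2c(-c3c(Cl)cccc3Cl)noc2C2CC2)nc1C(F)(F)F` is the reference point: in an assay on isolated protein for agonist activity at Bile acid receptor (Homo sapiens), read by FRET (on this read-out lower numbers stand for smaller maximal responses and higher numbers for larger maximal responses), compound 1 gives 109%. Compound 2 `CC(Oc1cccc(C(=O)O)c1)c1ccc(OCc2c(-c3c(Cl)cccc3Cl)noc2C2CC2)nc1C(F)(F)F` carries 1-(3-carboxyphenoxy)ethyl in place of (4-carboxybenzyl)(methyl)amino on an aromatic carbon, and in this assay compound 2 gives 102%. The step of a number 7 percentage points lower from compound 1 to compound 2 (within the scatter) falls within the scatter, so compound 2 sits with compound 1 at a full maximal response; no order between the two can be read from these numbers.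

Compound 3 `CC(Oc1ccc(C(=O)O)cc1)c1ccc(OCc2c(-c3c(Cl)cccc3Cl)noc2C2CC2)nc1C(F)(F)F` is not yet measured. It differs from compound 2 by 4-carboxyphenyl in place of 3-carboxyphenyl on an oxygen on a saturated carbon. Among the compounds with values here, the only measured step, a number 7 percentage points lower from compound 1 to compound 2 (within the scatter), bears on it indirectly: there a 4-carboxy arrangement (in compound 1) and a 3-carboxy arrangement (in compound 2) both reached the top of the scale, and the step between them stayed within the scatter. The expectation for this assay is therefore a step of no more than the scatter, in no particular direction, a number 2 percentage points higher from compound 2 to compound 3 (within the scatter). Compound 3 is estimated at 104%, with a range from 88% to 120%.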

Compound 3, largest response reached (reported as efficacy), in percent of the reference or control that the assay uses: 89%
For compound 3 the middle estimate is 15 percentage points above the measured one; the range from low to high includes it.
By their numbers in this assay, from the lowest: compound 3; then compounds 2 and 1 (each within the scatter of the next).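

Within the data shown here, on an oxygen on a saturated carbon, 4-carboxyphenyl in place of 3-carboxyphenyl is the first change to clear the scatter in this assay, with a number 13 percentage points lower from compound 2 to compound 3 (beyond the scatter), so within this pair the response depends on which carboxyphenyl isomer is attached. The wider exchange, 1-(4-carboxyphenoxy)ethyl in place of (4-carboxybenzyl)(methyl)amino, gives a number 20 percentage points lower from compound 1 to compound 3 (beyond the scatter), which shows that a 4-carboxy label alone does not keep the response at the level of compound 1 and that the rest of the group also counts. Compound 3 is therefore the lowest of the three, beyond the scatter from both others, but nothing available explains this drop.

Still open, as far as these compounds go, is whether 2-carboxyphenyl on the same oxygen would lie with compound 2, with compound 3 or elsewhere, and whether 4-carboxybenzyl on that oxygen would return the response to the level of compound 1. Also open, from the compounds shown here alone, is whether a (3-carboxybenzyl)(methyl)amino group would show the same dependence on the isomer, since the present step comes from a single pair.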